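The compounds below may be only part of what the source reports. "The series", "measured", "known", "first", "only" and "open" are said of these compounds alone.

Measured compounds:
compound 1 `Cc1ccc(-c2csc(NC(=O)COc3ccc(Br)cc3)n2)cc1` – 40900 nM
compound 2 `Cc1ccc(-c2csc(NC(=O)COc3ccccc3C(C)C)n2)cc1` – 55500 nM

Of the compounds shown here, two sharing one core have been measured in a functional assay on MDA-MB-468 cells (Homo sapiens) for cytotoxicity, read by MTT assay, with a stated time of 48 h; a higher number here means a weaker inhibitor, a lower number a stronger inhibitor. Compound 1 gives 40900 nM, and compound 2 gives 55500 nM. Compound 1 holds the smaller of the two numbers, but its gap to compound 2 lies within the usual scatter of this assay, so the two are not separated in any meaningful way, and both sit far up the concentration scale as weak inhibitors.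

Compound 3 `Cc1ccc(-c2csc(NC(=O)COc3ccc(F)cc3)n2)cc1` has not yet been measured. It differs from compound 1 by fluoro in place of bromo on an aromatic carbon. Among the measured compounds shown here, no pair of measured compounds shows a change of this kind, so there is no measured step to lean on. For the measured compounds named here, with only two weak values available, and a single halogen exchange at one aromatic carbon, the expectation is for a number near that of compound 1, with perhaps a mild drift towards a higher value. The step expected is a 1.5-fold higher number from compound 1 to compound 3 (0.17 log units; within the scatter), not clearly beyond the scatter. Compound 3 is therefore estimated at about 60000 nM in this assay, with a range from 28000 nM to 130000 nM.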

Compound 3, half-maximal inhibitory concentration: 24900 nM
The estimate for compound 3 lay 2.4-fold (0.38 log units) above the measured number; the measured number lies below the stated range.
By their numbers in this assay, from the lowest: compounds 3, 1 and 2 (each within the scatter of the next, the first and the last beyond it).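

In this assay, among the compounds shown here, the exchange of bromo for fluoro on an aromatic carbon, para to a large group, gives a 1.6-fold lower number from compound 1 to compound 3 (0.22 log units; within the scatter) and is the first single-place change that can be read. For the compounds shown here, at this position, the 4-bromophenoxy and 4-fluorophenoxy forms of the shared core therefore cannot be told apart in this assay, even though the two halogens are the only difference between compound 1 and compound 3. No measurement on hand offers an explanation for this result, so the step can only be recorded as it stands.

The compounds shown leave open whether any group at this position can move the number beyond the usual scatter, for example an amine, a carboxylic acid, a methoxy group or a nitrile, since only two halogens have been compared here. They also leave open whether changes elsewhere on the shared core, such as replacing the methyl group on the far aromatic ring with a longer chain, would matter more than this exchange.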